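Series notes: bromo in place of nitro

The source may report more compounds than this note shows. Statements on the series, on what has been measured and on what is new or still open speak of the compounds shown alone.

Measured so far:
- compound 1, `COc1cc(OC)c(-c2cc(=O)c3ccc(O)cc3o2)cc1OC`: 2.27 ug/mL
- compound 2, `COc1cc(OC)c(C(=O)/C=C/c2cc(OC)c(OC)cc2OC)c(OC)c1`: 1.98 ug/mL
- compound 3, `COc1cc(OC)c(OC)cc1/C=C/C(=O)c1ccc([N+](=O)[O-])cc1`: 1.98 ug/mL

All three numbers come from a functional assay, read by Griess assay, with a stated time of 2.5 h; a higher number here means a weaker inhibitor, a lower number a stronger inhibitor. Compound 3 sits level with compound 2 at the digits shown, the two together the lowest of the three numbers; its nearest neighbour is compound 2, with no change at the digits shown, and its furthest is compound 1, whose number is higher by an amount that stays within the scatter. The three values therefore cannot be ordered against each other, and none of the three can be called the strongest or weakest.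

Compound 4, `COc1cc(OC)c(OC)cc1/C=C/C(=O)c1ccc(Br)cc1`, has not yet been measured in this assay. It differs from compound 3 in one place: bromo in place of nitro on an aromatic carbon. Among the measured compounds shown here, no pair of measured compounds differing in one place is available, so the size of such a step has no precedent in this set. Given that compound 3 gives 1.98 ug/mL and that the whole set spans no more than the scatter, no step beyond the scatter is expected in either direction from compound 3 to compound 4. Compound 4 is estimated at 2.3 ug/mL, with a range from 1 ug/mL to 5 ug/mL. This estimate means an expected step of a 1.2-fold higher number from compound 3 to compound 4 (0.07 log units; within the scatter).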

Compound 4, half-maximal inhibitory concentration: 2.22 ug/mL
Compound 4: the middle estimate sits 1.0-fold (0.02 log units) above what was measured; the range from low to high includes it.
By their numbers in this assay, from the lowest: compounds 2, 3, 4 and 1 (each within the scatter of the next).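

In this assay, among the compounds shown here, compounds 3 and 4 form the first pair that differs in one place, and the step is a 1.1-fold higher number from compound 3 to compound 4 (0.05 log units; within the scatter). On an aromatic carbon para to a large group, bromo can therefore stand in place of nitro, with its hydrogen-bond acceptors and its double bond outside aromatic rings gone, while the number stays within the scatter, so in this pair the read-out does not depend on those features of the nitro group. Nothing available explains why the two groups read alike.

As far as these compounds go, this is a single pair at a single position, so it remains open whether an amine, a carboxylic acid or a longer alkyl chain on the same aromatic carbon would also stay within the scatter, or whether any group there would move the number beyond it. From the compounds shown here alone, it is also open whether bromo in place of nitro would give a similarly small step on a different core, and how much of the number depends on the methoxy groups that compounds 3 and 4 share.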